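Adding a Second Chlorine to the Pyrazole Aryl Group

A few compounds are considered here, and "the series" means these few. Any claim that something is new, unique, unknown or untested is made for them only; others in the source may bear on it.

The two measured compounds share one core and differ only in the aryl group on the aromatic nitrogen. Compound 1 `Cc1ccc(-c2nn(-c3ccc(F)cc3)cc2C(=O)Nc2ccc(C)c(S(=O)(=O)N3CCOCC3)c2)cc1` gives 24.3 nM in an assay on isolated protein for antagonist activity at Bile acid receptor (Homo sapiens), read by TR-FRET, with a stated time of 20 min; a lower number here means a stronger inhibitor, a higher number a weaker inhibitor. Among the measured compounds shown here, compound 2 `Cc1ccc(-c2nn(-c3cccc(Cl)c3)cc2C(=O)Nc2ccc(C)c(S(=O)(=O)N3CCOCC3)c2)cc1` gives 10.4 nM in this assay, the lowest of the two numbers, and the step of a 2.3-fold lower number from compound 1 to compound 2 (0.37 log units; beyond the scatter) is the only measured change at this position. Compound 3 `Cc1ccc(-c2nn(-c3ccc(Cl)cc3Cl)cc2C(=O)Nc2ccc(C)c(S(=O)(=O)N3CCOCC3)c2)cc1` carries the change 2,4-dichlorophenyl in place of 3-chlorophenyl on an aromatic nitrogen and has not yet been measured in this assay.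

For the measured compounds named here, only one step bears on this change, and it shows that exchanging one halogen pattern for another on this aryl ring moved the number modestly. Going by the values given here, that gives limited guidance, as no measured pair shows what a second chlorine does here. A step of modest size in either direction, or none beyond the scatter, is therefore expected from compound 2 to compound 3, with the estimate leaning slightly toward a higher number. Compound 3 is expected to give 15 nM in this assay, within a range from 5 nM to 45 nM, meaning an estimated step of a 1.4-fold higher number from compound 2 to compound 3 (0.16 log units; within the scatter).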

Compound 3, half-maximal inhibitory concentration: 14.1 nM
Compound 3: middle estimate off by 1.1-fold (0.03 log units), on the high side; measured number inside the range.
By their numbers in this assay, from the lowest: compounds 2, 3 and 1 (each within the scatter of the next, the first and the last beyond it).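

In this assay, the 2,4-dichlorophenyl group of compound 3 cannot be told apart from the 3-chlorophenyl group of compound 2, with a 1.4-fold higher number from compound 2 to compound 3 (0.13 log units; within the scatter) as the step between them. Set against the 4-fluorophenyl group, the same ring gives a 1.7-fold lower number from compound 1 to compound 3 (0.24 log units; within the scatter) and so also stays inside the usual variation between repeat measurements, which places compound 3 within the scatter of both earlier compounds, even though those two lie beyond the scatter of each other. The new information is that this aromatic nitrogen can carry a phenyl ring with two chlorines and still give a number in the same low range as the rings with a single halogen. No measurement is available here that could explain why these three aryl groups give such similar numbers.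

All three compounds shown carry only halogens on this ring, so it remains open what an unsubstituted phenyl ring, a methoxy group, a nitrile or a carboxylic acid would do here. Also open, going by these compounds, is whether a non-aromatic group such as cyclohexyl, or a simple alkyl chain, could take the place of the aryl ring and keep the number in this range.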